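Swapping Bromo for Nitro on the Benzyl Ether

The compounds below may be only part of what the source reports. "The series", "measured", "known", "first", "only" and "open" are said of these compounds alone.

Values in a functional assay on HCT-116 cells (Homo sapiens) for antiproliferative activity, read by MTT assay, with a stated time of 24 h; on this read-out lower numbers stand for stronger inhibition and higher numbers for weaker inhibition:
compound 1 `COc1cc(OC)c(-c2coc3cc(OCc4ccccc4)ccc3c2=O)cc1OC` gives 2280 nM
compound 2 `COc1cc(OC)c(-c2coc3cc(OCc4ccccc4F)ccc3c2=O)cc1OC` gives 2900 nM
compound 3 `COc1cc(OC)c(-c2coc3cc(OCc4ccc(Br)cc4)ccc3c2=O)cc1OC` gives 1980 nM

The three compounds share one core and differ only on the benzyl ring. Compound 3 stands level with the other two, since none of the gaps around it goes beyond the scatter. Its nearest neighbour shows a 1.2-fold lower number from compound 1 to compound 3 (0.06 log units; within the scatter), and its furthest shows a 1.5-fold lower number from compound 2 to compound 3 (0.17 log units; within the scatter).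

Compound 4 `COc1cc(OC)c(-c2coc3cc(OCc4ccc([N+](=O)[O-])cc4)ccc3c2=O)cc1OC` is still unmeasured. It has nitro in place of bromo on an aromatic carbon of a six-membered aromatic ring of carbon only, para to a large group (nitro in place of bromo on an aromatic carbon). Among the measured compounds shown here, no nitro compound has been measured, so the evidence is indirect. The nearest guides are the two other changes on that ring, a 1.3-fold higher number from compound 1 to compound 2 (0.10 log units; within the scatter) and a 1.2-fold lower number from compound 1 to compound 3 (0.06 log units; within the scatter), and both are small. Across these three compounds, then, the ring substituent has not moved the number measurably. A similar result is expected here, with no step beyond the scatter in either direction, although three compounds are a thin basis for a new group.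

The expected step is a 1.1-fold higher number from compound 3 to compound 4 (0.05 log units; within the scatter).

For compound 4 the estimated value is 2200 nM, with an expected range from 1000 nM to 4800 nM.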

Compound 4, half-maximal inhibitory concentration: > 10000 nM
Compound 4 gave a limit, no number (the forecaster's own chance of this, stated with the estimate: 3%); at least 4.5-fold (0.65 log units) between middle value and limit.
By their numbers in this assay, from the lowest: compounds 3, 1 and 2 (each within the scatter of the next). At a limit, above all of these: compound 4.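

In this assay compound 4 gives > 10000 nM, which is a limit of the assay and not a number. Among the compounds shown here, at this place on the benzyl ring, para to a large group, hydrogen and bromo stayed within the scatter of each other, with a 1.2-fold lower number from compound 1 to compound 3 (0.06 log units; within the scatter), so the position had looked indifferent to its substituent; nitro is the first change on the ring to go beyond the scatter, with an at least 5.0-fold higher number from compound 3 to compound 4 (0.70 log units; beyond the scatter), an at least 4.3-fold higher number from compound 1 to compound 4 (0.64 log units; beyond the scatter) and an at least 3.4-fold higher number from compound 2 to compound 4 (0.53 log units; beyond the scatter). The tolerance seen among compounds 1, 2 and 3 therefore does not extend to every group at this place, and each of the three new steps gives only a lower bound, set by a single value: the limit of > 10000 nM in this assay, at which 1 of the 4 values shown sits.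

The true size of the step stays open, since the compounds shown give no number for compound 4. Also open, going by these compounds, is whether an amine or a nitrile on the same aromatic carbon would stay level with compound 3 or fall beyond the scatter as compound 4 does, so nitro remains a single case.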